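Fluoro for nitro: cytotoxicity working notes

A few compounds are considered here, and "the series" means these few. Any claim that something is new, unique, unknown or untested is made for them only; others in the source may bear on it.

Measured compounds:
compound 1, `COc1ccc(Oc2ccccc2-c2ccsc2S(=O)(=O)N2CCN(C(=O)Nc3ccc([N+](=O)[O-])cc3)CC2)cc1OC`: > 20000 nM
compound 2, `COc1ccc(Oc2ccc([N+](=O)[O-])cc2-c2ccsc2S(=O)(=O)N2CCN(C(=O)Nc3ccc([N+](=O)[O-])cc3)CC2)cc1OC`: > 20000 nM

In an ADME assay on HEK-293T cells (Homo sapiens) for cytotoxicity, read by CCK-8 assay, with a stated time of 48 h (on this read-out lower numbers stand for stronger inhibition and higher numbers for weaker inhibition), compound 1 gives > 20000 nM, which is a limit of the assay and not a number. Compound 2 likewise gives > 20000 nM, again a limit. Going by the values given here, the only step between measured compounds, a step that the two limits leave unreadable from compound 1 to compound 2, has no readable size because of the limit of > 20000 nM in this assay, at which 2 of the 2 values shown sit. On the numbers shown, compound 1 therefore stands only at that limit, with nothing to place it more finely.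

Compound 3, `COc1ccc(Oc2ccccc2-c2ccsc2S(=O)(=O)N2CCN(C(=O)Nc3ccc(F)cc3)CC2)cc1OC`, differs from compound 1 by fluoro in place of nitro on an aromatic carbon. Among the compounds with values here, no measured step covers this change, and the one step that exists cannot be read. Nothing shown supports an expectation of a step of readable size in this assay. Compound 3 is expected to remain at the limit, as compound 1 does. For compound 3 the expected step is a step that the limit leaves unreadable from compound 1 to compound 3. Compound 3 is expected to give 30000 nM in this assay, within 15000 nM to 100000 nM.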

Compound 3, half-maximal inhibitory concentration: > 50000 nM
Compound 3 was reported as a limit (the forecaster's own chance of this, stated with the estimate: 85%); middle value at least 1.6-fold (0.22 log units) from the limit.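

No new step can be read: compound 1 and compound 3 both stand only as limits in this assay, leaving fluoro in place of nitro without a readable size. The compounds shown leave open whether this change alters cytotoxicity at all.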